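Compound 2 gives up 2,5-dioxoimidazolidin-1-yl for methoxy

The source may hold more compounds than are shown below. What is called first, only, known or untested is meant among the compounds shown, and "the series" means these compounds.

Among the compounds with values here, in a physicochemical assay for lipophilicity, read by HPLC, measured as octanol-water partition (a higher number here means a more lipophilic compound, a lower number a more polar compound), compound 2 (`O=C1CNC(=O)N1C[C@H]1CN(c2ccc(-n3cc(-c4ccccn4)cn3)c(F)c2)C(=O)O1`) gives 1.25 and stands lowest of the two numbers so far, with compound 1 (`CN(CCC#N)C[C@H]1CN(c2ccc(-n3cc(-c4ccccn4)cn3)c(F)c2)C(=O)O1`) at 1.9 above it. Compound 3 (`COC[C@H]1CN(c2ccc(-n3cc(-c4ccccn4)cn3)c(F)c2)C(=O)O1`) carries methoxy in place of 2,5-dioxoimidazolidin-1-yl on a saturated chain carbon bound to a saturated ring carbon. Within the data shown here, the only measured step that bears on this (a number 0.65 log units lower from compound 1 to compound 2 (beyond the scatter)) brought that same 2,5-dioxoimidazolidin-1-yl in, in place of (2-cyanoethyl)(methyl)amino. Here it leaves, so a rise of similar modest size is expected (a number 0.75 log units higher from compound 2 to compound 3 (beyond the scatter)). Compound 3 is estimated at 2 (range 1.6 to 2.4).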

Compound 3, partition coefficient: 2.18
Compound 3: the middle estimate sits 0.18 log units below what was measured; measured number inside the range.
By their numbers in this assay, from the lowest: compound 2; then compounds 1 and 3 (each within the scatter of the next).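

In this assay methoxy on a saturated chain carbon bound to a saturated ring carbon gives a number 0.93 log units higher from compound 2 to compound 3 (beyond the scatter) and so more than recovers the ground lost with 2,5-dioxoimidazolidin-1-yl. The same group gives a number 0.28 log units higher from compound 1 to compound 3 (within the scatter) and so two very different groups, methoxy and (2-cyanoethyl)(methyl)amino, read alike here while compound 2 alone stands apart. Nothing available gives a reason for this.

From the compounds shown here alone, whether the ring, the carbonyls or the amide hydrogen of compound 2 sets it apart stays open. Going by these compounds, how a hydroxyl, a primary amine or a carboxylic acid would read at this place also remains unknown.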